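The source may report more compounds than this note shows. Statements on the series, on what has been measured and on what is new or still open speak of the compounds shown alone.

Compound 1 `O=c1cc(-c2ccccc2)oc2c(OCCCCNC3CCCCC3)c(O)cc(O)c12` has in a functional assay on A549 cells (Homo sapiens) for cytotoxicity, read by MTT assay, with a stated time of 48 h (on this read-out higher numbers stand for weaker inhibition and lower numbers for stronger inhibition), only the entry "not determined" (no result reported), so it stands without a number on this read-out. The only measured anchor in the set is compound 2 `COc1c(OCCCCN2CCCCC2)cc(O)c2c(=O)cc(-c3ccccc3)oc12`, which in this assay gives 1150 nM. The step under consideration leads from compound 1 to compound 3 `O=c1cc(-c2ccccc2)oc2c(OCCCN3CCCC3)c(O)cc(O)c12`, and the structural change is pyrrolidin-1-yl in place of (cyclohexylamino)methyl on a saturated chain carbon, three bonds along the chain from an oxygen on an aromatic ring. For the measured compounds named here, no measured pair shows what this change does in this assay, and compound 1 itself offers no value to build on, so any expectation rests on the single number of compound 2 and on the modest size of the change. No step beyond the usual scatter is expected for this exchange in this assay, in either direction. On that basis compound 3 is estimated to give about 1500 nM in this assay, with a range from 400 nM to 6000 nM that reflects the thin footing of the estimate.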

Compound 3, half-maximal inhibitory concentration: > 100000 nM
Compound 3 gave a limit, no number (the forecaster's own chance of this, stated with the estimate: 10%); middle value at least 66-fold (1.82 log units) from the limit.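

For the compounds shown here, no step from compound 1 to compound 3 can be read in this assay, as neither offers a number there. For compound 3, the entry > 100000 nM is a limit. The compounds shown leave open what pyrrolidin-1-yl in place of (cyclohexylamino)methyl does on its own in this assay.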